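A few compounds are considered here, and "the series" means these few. Any claim that something is new, unique, unknown or untested is made for them only; others in the source may bear on it.

Measured compounds:
- compound 1 `CC(C)C(c1ccc(-c2ccc3cccc(F)c3c2)[nH]c1=O)N1CCCCS1(=O)=O`: 0.0733 h
- compound 2 `CC(C)C(c1ccc(-c2ccc3cccc(F)c3c2)[nH]c1=O)N1CCN/C1=N\C#N`: 0.207 h

Within the data shown here, in an ADME assay on microsomes from liver (Mus musculus) for metabolic stability (on this read-out higher numbers stand for a longer-lived compound and lower numbers for a shorter-lived compound), compound 1 gives 0.0733 h, the lowest of the two numbers recorded; the only neighbour is compound 2, which in this assay gives 0.207 h, and the step of a 2.8-fold higher number from compound 1 to compound 2 (0.45 log units; beyond the scatter) is a modest rise. Compound 3 `CC(C)C(Cc1nnn[nH]1)c1ccc(-c2ccc3cccc(F)c3c2)[nH]c1=O` has not yet been measured in this assay. Its difference from compound 1 is a group of 6 heavy atoms (2 carbon, 4 nitrogen; one five-membered aromatic ring with 4 hetero atoms) in place of a group of 8 heavy atoms (4 carbon, 1 nitrogen, 2 oxygen, 1 sulfur; one six-membered non-aromatic ring with 2 hetero atoms), on a saturated chain carbon bound to an aromatic carbon and a saturated chain carbon.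

Among the measured compounds shown here, the one measured step that bears on this change is the step from compound 1 to compound 2, where a different group was put in at the same place on the saturated chain carbon; that step, a 2.8-fold higher number from compound 1 to compound 2 (0.45 log units; beyond the scatter), lies beyond the scatter. The change to compound 3 likewise removes the six-membered non-aromatic ring with 2 hetero atoms and puts a smaller, nitrogen-rich group in its place, so a step in the same direction, of roughly similar modest size, is expected in this assay, though a single precedent leaves the size uncertain.

For compound 3 the estimated step is a 2.0-fold higher number from compound 1 to compound 3 (0.31 log units; beyond the scatter). The expected value of compound 3 in this assay is therefore 0.15 h, with a range from 0.05 h to 0.45 h.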

Compound 3, half-life: 0.853 h
Compound 3: the middle estimate sits 5.7-fold (0.75 log units) below what was measured; the whole stated range lies below it.
By their numbers in this assay, from the lowest: compound 1; then compound 2; then compound 3.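

In this assay, putting (1H-tetrazol-5-yl)methyl on the saturated chain carbon gives a 12-fold higher number from compound 1 to compound 3 (1.07 log units; beyond the scatter), and the same group also exceeds the five-membered non-aromatic ring, with a 4.1-fold higher number from compound 2 to compound 3 (0.61 log units; beyond the scatter). The single earlier step had shown only a modest rise at this place; the three compounds now show that a change of this one group can move the half-life by a large step, and the order runs from the six-membered non-aromatic ring through the five-membered non-aromatic ring to the five-membered aromatic ring with 4 hetero atoms. The data shown offer nothing that explains why this group gives the longest half-life of the three.

The compounds shown do not separate the contribution of the aromatic ring with 4 hetero atoms from that of the methyl carbon joining it to the saturated chain carbon, a question that a 1H-tetrazol-5-yl ring bound directly there would address. From the compounds shown here alone, whether the rise is peculiar to this ring also stays open, and a carboxylic acid at the end of the same methyl carbon would test that.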